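The source may report more compounds than this note shows. Statements on the series, on what has been measured and on what is new or still open speak of the compounds shown alone.

Three compounds have so far been measured in an assay on Sf9 cells for inhibition of protein deacetylase HDAC6 (Homo sapiens), read by fluorescence, with a stated time of 90 min; on this read-out lower numbers stand for stronger inhibition and higher numbers for weaker inhibition:

Compound 1 `O=C(CN(Cc1ccc(C(=O)NO)cc1)C(=O)c1cccc2ccccc12)NCc1ccccc1`: 10 nM
Compound 2 `CC(C)c1ccc(C(=O)N(Cc2ccc(C(=O)NO)cc2)C(C)(C)C(=O)NCc2ccccc2)cc1`: 60 nM
Compound 3 `CN(C)c1ccc(C(=O)N(Cc2ccc(C(=O)NO)cc2)C(C)(C)C(=O)NCc2ccccc2)cc1`: 70 nM

Compound 1 gives the lowest number of the three, and the gaps to compound 2 and to compound 3 both lie beyond the usual scatter. Between compound 2 and compound 3 the only measured single-point step, a 1.2-fold higher number from compound 2 to compound 3 (0.07 log units; within the scatter), concerns an aromatic substituent and is too small to read anything from.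

Compound 4 `Cc1ccccc1C(=O)N(CC(=O)NCc1ccccc1)Cc1ccc(C(=O)NO)cc1` differs from compound 1 in one place: 2-methylphenyl in place of naphthalen-1-yl on a carbonyl carbon. Among the compounds with values here, no measured step makes this exchange, so the size of its effect cannot be taken from the data directly. Compound 2 and compound 3, which carry one six-membered aromatic ring on that carbonyl carbon but also differ from compound 1 elsewhere, give higher numbers than compound 1. A moderate rise in the number is therefore expected for compound 4, by about a 2.5-fold higher number from compound 1 to compound 4 (0.40 log units; beyond the scatter), though the uncertainty is wide. The estimate for compound 4 in this assay is 25 nM, with a likely range from 8 nM to 80 nM.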

Compound 4, half-maximal inhibitory concentration: 30 nM
The estimate for compound 4 lay 1.2-fold (0.08 log units) below the measured number; low and high end bracket the measured number.
By their numbers in this assay, from the lowest: compound 1; then compounds 4, 2 and 3 (each within the scatter of the next, the first and the last beyond it).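

In this assay, within the data shown here, the exchange of naphthalen-1-yl for 2-methylphenyl on the carbonyl carbon gives a 3.0-fold higher number from compound 1 to compound 4 (0.48 log units; beyond the scatter), the first measured step at this position with the rest of the molecule unchanged. The step is beyond the usual scatter but modest: with one six-membered aromatic ring in place of two, compound 4 still gives 30 nM, so the second ring is not essential for a number in this range. No measurement shown explains the rise.

This single exchange removes a ring and introduces a methyl group at once, so the contribution of each remains unseparated. Also open, from the compounds shown here alone, is how the number would respond to plain phenyl, to a pyridine ring, or to a ring carrying a carboxylic acid at this position.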